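The source may report more compounds than this note shows. Statements on the series, on what has been measured and on what is new or still open speak of the compounds shown alone.

Compound 1 `C=C1CC[C@H]2[C@@](C)(CC[C@@H](OC(C)=O)[C@@]2(C)C(=O)OCc2ccccc2)[C@@H]1CCC1=CCOC1=O` and compound 2 `C=C1CC[C@H]2[C@@](C)(CC[C@@H](O)[C@@]2(C)C(=O)OCc2ccccc2)[C@@H]1CCC1=CCOC1=O` share one core, and in a functional assay on NIH3T3 cells (Mus musculus) for inhibition, read by MTT assay, with a stated time of 72 h (a lower number here means a stronger inhibitor, a higher number a weaker inhibitor), compound 1 gives 12900 nM while compound 2 gives 37900 nM. The change between them, (hydrogen in place of acetyl on an oxygen on a saturated carbon), produced a 2.9-fold higher number from compound 1 to compound 2 (0.47 log units; beyond the scatter). Compound 3 `C=C1CC[C@H]2[C@@](C)(CC[C@@H](OC(C)=O)[C@@]2(C)C(=O)OC)[C@@H]1/C=C/C1=CCOC1=O` has a core whose difference from that of compound 1 is not broken down here; in this assay compound 3 gives 32300 nM. Compound 4 `C=C1CC[C@H]2[C@@](C)(CC[C@@H](O)[C@@]2(C)C(=O)OC)[C@@H]1/C=C/C1=CCOC1=O` relates to compound 3 by hydrogen in place of acetyl on an oxygen on a saturated carbon, the same change as that from compound 1 to compound 2, at the same place. Because a 2.9-fold higher number from compound 1 to compound 2 (0.47 log units; beyond the scatter) was modest but beyond the scatter, a step of similar size is expected, namely a 2.5-fold higher number from compound 3 to compound 4 (0.39 log units; beyond the scatter). The estimate for compound 4 in this assay is therefore 80000 nM, expected to lie between 35000 nM and 200000 nM.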

Compound 4, half-maximal inhibitory concentration: 111000 nM
Beside the measured number, compound 4's estimate is 1.4-fold (0.14 log units) below it; low and high end bracket the measured number.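

In this assay the change from acetoxy to hydroxy gave a 3.4-fold higher number from compound 3 to compound 4 (0.54 log units; beyond the scatter) and so again went with weaker inhibition. Set beside the earlier step, the new one agrees with it in direction and size: the same change on two cores in this assay, a 2.9-fold higher number (0.47 log units; beyond the scatter) from compound 1 to compound 2 and a 3.4-fold higher number (0.54 log units; beyond the scatter) from compound 3 to compound 4, 1.2-fold (0.07 log units) apart, within the scatter of two such steps. The change therefore carried over between these two cores, but two pairs do not show that it would hold on any other core, and they do not explain why it has this effect.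

Among the compounds shown, only acetyl and hydrogen stand on this oxygen. Going by these compounds, how a longer acyl chain, or an amine in place of the oxygen, would read in this assay remains open.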